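The source may hold more compounds than are shown below. What is called first, only, known or untested is meant among the compounds shown, and "the series" means these compounds.

Measured in an ADME assay on Vero cells (Chlorocebus sabaeus) for cytotoxicity, read by MTT assay, with a stated time of 96 h; a lower number here means that less compound is tolerated, a higher number that more compound is tolerated:
- compound 1 `COc1cc(NCc2ccc(C)s2)ccc1-c1cnco1`: 24700 nM
- compound 2 `COc1cc(NCc2scnc2C)ccc1-c1cnco1`: 73700 nM

Of these two, compound 2 holds the higher number at 73700 nM, so it is the better tolerated of the pair in this assay. The next compound, compound 3 `COc1cc(NCc2ccc(Cl)s2)ccc1-c1cnco1`, has not yet been measured. It differs from compound 2 as follows: 5-chlorothiophen-2-yl in place of 4-methyl-1,3-thiazol-5-yl on a saturated chain carbon bound to a nitrogen on an aromatic ring. In words, 5-chlorothiophen-2-yl takes the place of 4-methyl-1,3-thiazol-5-yl on a saturated chain carbon bound to a nitrogen on an aromatic ring.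

Going by the values given here, only one measured step bears on this change: a 3.0-fold higher number from compound 1 to compound 2 (0.47 log units; beyond the scatter). That modest step replaced 5-methylthiophen-2-yl with 4-methyl-1,3-thiazol-5-yl, and the change to compound 3 runs the opposite way. However, the incoming group carries chlorine rather than methyl, and no measured compound shows what that difference does. A modest step of similar size towards a lower number in this assay is therefore expected, with wide uncertainty. The expected step is a 3.2-fold lower number from compound 2 to compound 3 (0.51 log units; beyond the scatter). For compound 3 the estimated value is 23000 nM, with an expected range from 9000 nM to 60000 nM.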

Compound 3, half-maximal cytotoxic concentration: 53800 nM
Beside the measured number, compound 3's estimate is 2.3-fold (0.37 log units) below it, and the stated range covers the measured number.
By their numbers in this assay, from the lowest: compound 1; then compounds 3 and 2 (each within the scatter of the next).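

In this assay, 5-chlorothiophen-2-yl in place of 4-methyl-1,3-thiazol-5-yl gives a 1.4-fold lower number from compound 2 to compound 3 (0.14 log units; within the scatter), so at this place, on a saturated chain carbon bound to a nitrogen on an aromatic ring, a thiophene ring does not by itself go with the low number of compound 1. What the thiophene ring carries makes the difference here: chloro in place of methyl on an aromatic carbon gives a 2.2-fold higher number from compound 1 to compound 3 (0.34 log units; beyond the scatter), and this step, unlike the one from the thiazole, lies beyond the scatter. Nothing available gives a reason why chloro and methyl on this ring part in this way.

The compounds shown leave open whether an unsubstituted thiophene, or a bromo or trifluoromethyl group on the same ring carbon, would fall with compound 1 or with compound 3. From the compounds shown here alone, it also remains open whether chloro would have a similar effect on the 1,3-thiazole ring, and how a longer chain on the nitrogen would change the number.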